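Aryl amide variation in the cyclopropylsulfonamide piperidine series

The source may hold more compounds than are shown below. What is called first, only, known or untested is meant among the compounds shown, and "the series" means these compounds.

Measured compounds:
compound 1, `NC(=O)c1ccc(C(=O)N2CCC(N(C3CC3)S(=O)(=O)c3cccc(C(F)(F)F)c3)CC2)cc1`: 0%
compound 2, `O=C(c1ccc(OC(F)(F)F)cc1)N1CCC(N(C2CC2)S(=O)(=O)c2cccc(C(F)(F)F)c2)CC1`: 88%
compound 3, `CS(=O)(=O)c1ccc(C(=O)N2CCC(N(C3CC3)S(=O)(=O)c3cccc(C(F)(F)F)c3)CC2)cc1`: "not determined" (no result reported)

All numbers come from an assay on cells for inhibition of Voltage-dependent L-type calcium channel subunit alpha-1C (Homo sapiens), read by FLIPR and calcium flux, tested at 3 uM; on this read-out higher numbers stand for a stronger effect at the one concentration tested and lower numbers for a weaker effect. Among the compounds with values here, compound 1 gives 0% while compound 2 gives 88%, so a number 88 percentage points higher from compound 1 to compound 2 (beyond the scatter) is the only measured step in the set. Compound 3 has no number in this assay; it cannot be placed relative to compound 1 or compound 2, and the step from compound 3 to compound 4 therefore starts from an unknown point.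

Compound 4, `NC(=O)c1ccccc1C(=O)N1CCC(N(C2CC2)S(=O)(=O)c2cccc(C(F)(F)F)c2)CC1`, differs from compound 3 by 2-carbamoylphenyl in place of 4-(methylsulfonyl)phenyl on a carbonyl carbon. Within the data shown here, no measured step covers this exact exchange. Among the measured compounds shown here, the one step that bears on it, a number 88 percentage points higher from compound 1 to compound 2 (beyond the scatter), shows that a carbamoyl group on the aryl amide of this core went with the weak end of the range. Compound 4 also carries a carbamoyl group on that aryl amide, as 2-carbamoylphenyl, so its value in this assay is expected to lie near that of compound 1 rather than compound 2. Compound 4 is estimated at 15%, with a range from 0% to 45%.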

Compound 4, a percentage reported as inhibition, at one concentration (the size of the read-out at that concentration, not a potency): 17%
Beside the measured number, compound 4's estimate is 2 percentage points below it; the measured number falls inside the stated range.
By their numbers in this assay, from the lowest: compound 1; then compound 4; then compound 2.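

In this assay, 2-carbamoylphenyl in place of 4-(trifluoromethoxy)phenyl on the carbonyl carbon gives a number 71 percentage points lower from compound 2 to compound 4 (beyond the scatter), so the weak end of the range now holds two carbamoyl compounds and not just one. Within that pair, 2-carbamoylphenyl in place of 4-carbamoylphenyl gives a number 17 percentage points higher from compound 1 to compound 4 (beyond the scatter): where the carbamoyl group sits on the aromatic ring does shift the read-out, but this modest step stays well short of the large step away from the trifluoromethoxy compound. Nothing available explains either step.

Steps involving compound 3 cannot be read, so 4-(methylsulfonyl)phenyl remains unplaced in this series. Also open, from the compounds shown here alone, is whether a carboxylic acid or an amine on the aromatic ring would stay at the low end with the carbamoyl compounds, or reach the high value of compound 2.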